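This account rests on a few compounds, and the source may have more. Where it says the series, first, only, none or still open, it means among the compounds named here.

Compound 1 `O=C(Nc1cccc(-n2cc(-c3ccncc3)c(-c3ccc(Cl)c(O)c3)n2)c1)Nc1cccc(C(F)(F)F)c1` gives 10800 nM in a functional assay on SK-MEL-2 cells (Homo sapiens) for inhibition, read by sulforhodamine B assay, with a stated time of 48 h; a lower number here means a stronger inhibitor of growth, a higher number a weaker inhibitor of growth.
Compound 2 `COc1cc(-c2nn(-c3cccc(NC(=O)c4cccc(C(F)(F)F)c4)c3)cc2-c2ccncc2)ccc1Cl` gives a limit of this assay, > 50000 nM.
Compound 3 `COc1cc(-c2nn(-c3cccc(NC(=O)Nc4ccc(Cl)c(Cl)c4)c3)cc2-c2ccncc2)ccc1Cl` gives 2350 nM.

Compound 3 has the lowest of the two numbers shown; compound 1 sits higher, beyond the scatter, and the value of compound 2 is a limit and no number (the limit of > 50000 nM in this assay, at which 1 of the 3 values shown sits). The change to compound 4 `O=C(Nc1cccc(-n2cc(-c3ccncc3)c(-c3ccc(Cl)c(O)c3)n2)c1)Nc1ccc(Cl)c(Cl)c1` is hydrogen in place of methyl on an oxygen on an aromatic ring. Within the data shown here, the one measured step, an at least 21-fold lower number from compound 2 to compound 3 (1.32 log units; beyond the scatter), alters the group on the carbonyl carbon, not the oxygen on the aromatic ring, so it does not bear on this step. Compound 1 carries the hydroxy of compound 4 but differs from compound 3 in two places, so its higher number is only a weak pointer. Compound 4 is therefore expected to show a 1.5-fold higher number from compound 3 to compound 4 (0.17 log units; within the scatter), with an estimated 3500 nM, between 1200 nM and 10000 nM.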

Compound 4, concentration for total growth inhibition: 2640 nM
Compound 4: middle estimate off by 1.3-fold (0.12 log units), on the high side; the range from low to high includes it.
By their numbers in this assay, from the lowest: compounds 3 and 4 (each within the scatter of the next); then compound 1. At a limit, above all of these: compound 2.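

In this assay, methoxy to hydroxy on the aromatic ring gives a 1.1-fold higher number from compound 3 to compound 4 (0.05 log units; within the scatter), so this position, with 3,4-dichlorophenyl on the amide-type nitrogen, accepts either group within the scatter. Among these compounds, with hydroxy held in place, 3,4-dichlorophenyl in place of 3-(trifluoromethyl)phenyl gives a 4.1-fold lower number from compound 1 to compound 4 (0.61 log units; beyond the scatter), the first comparison of these two groups that differs in that one place alone. Nothing measured here gives a cause for either step. As far as these compounds go, whether a longer chain on this oxygen, such as ethoxy, or an amine in place of the methoxy would read the same remains open.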